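Lengthening the hydroxamate linker on the shared core

This account rests on a few compounds, and the source may have more. Where it says the series, first, only, none or still open, it means among the compounds named here.

Compound 1: `Nc1ncnc2c1c(-c1cnc3[nH]ccc3c1)nn2CCCC(=O)NO`, > 150000 nM
Compound 2: `Nc1nc2cc(-c3nn(CCCCCC(=O)NO)c4ncnc(N)c34)ccc2o1`, 19000 nM

In a functional assay on MDA-MB-231 cells (Homo sapiens) for inhibition, read by MTT assay, with a stated time of 72 h (a higher number here means a weaker inhibitor, a lower number a stronger inhibitor), compound 1 gives only a limit, > 150000 nM, so it sits at the limit of > 150000 nM in this assay, at which 1 of the 2 values shown sits. Compound 2, which carries a longer chain on a different aromatic partner, gives 19000 nM. Compound 3, `Nc1ncnc2c1c(-c1cnc3[nH]ccc3c1)nn2CCCCC(=O)NO`, differs from compound 1 by (hydroxycarbamoyl)methyl in place of hydroxycarbamoyl on a saturated chain carbon, three bonds along the chain from an aromatic nitrogen. For the measured compounds named here, with no measured step of this kind to lean on, the expected movement in this assay is a modest gain at best, possibly nothing beyond the scatter. Compound 3 is estimated at 80000 nM, within 20000 nM to 150000 nM. The expected step is an at least 1.8-fold lower number from compound 1 to compound 3 (0.27 log units; that floor lies within the scatter).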

Compound 3, half-maximal inhibitory concentration: > 50000 nM
Compound 3 was reported as a limit; the forecaster's own chance of this, stated with the estimate: 40%; the middle value does not contradict the limit.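

Compound 1 and compound 3 both stand only as limits in this assay, so no step can be read between them. The compounds shown leave open whether 4-(hydroxycarbamoyl)butyl in place of 3-(hydroxycarbamoyl)propyl on the shared core changes inhibition at all.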